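Amide Substitution and Stability of an Acrylamide Series

The source may hold more compounds than are shown below. What is called first, only, known or untested is meant among the compounds shown, and "the series" means these compounds.

Three compounds sharing one core have been examined in a physicochemical assay for pharmacokinetics, read by LC-MS, in phosphate buffer, at pH 7.4, in the presence of a further agent that is not named here; a lower number here means that the compound disappears faster, a higher number that the compound lasts longer. Compound 1 `C=CC(=O)N1CC(NC(=O)Cn2cc(C(=O)N3CCc4ccccc4C3)c3cc(Br)ccc32)C1` gives 1.67 h. Compound 2 `C=CC(=O)N1CC(NC(=O)Cn2cc(C(=O)N3CCc4c(F)cccc4C3)c3cc(Br)ccc32)C1` gives 1.67 h, and compound 3 `C=CC(=O)N1CC(NC(=O)Cn2cc(C(=O)N(C)Cc3ccccc3)c3cc(Br)ccc32)C1` gives 1.67 h, so compound 1 stands level with both. The step of no change at the digits printed from compound 1 to compound 2 (within the scatter) and the step of no change at the digits printed from compound 1 to compound 3 (within the scatter) both stay within the scatter. Compound 4 `C=CC(=O)N1CC(NC(=O)Cn2cc(C(=O)NCc3ccccc3)c3cc(Br)ccc32)C1` has not yet been measured; it differs from compound 1 by benzylamino in place of 1,2,3,4-tetrahydroisoquinolin-2-yl on a carbonyl carbon. The nearest measured comparison is the step of no change at the digits printed from compound 1 to compound 3 (within the scatter), where a different amine on the same carbonyl carbon left the half-life unchanged. On that basis no step beyond the scatter is expected in this assay, and the expected step is no change at the digits printed from compound 1 to compound 4 (within the scatter). Compound 4 is therefore estimated at 1.67 h, with a range from 0.9 h to 3.1 h.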

Compound 4, half-life: 1.67 h
Compound 4: the middle estimate sits on the measured number at the digits printed; measured number inside the range.
By their numbers in this assay, from the lowest: compounds 1, 2, 3 and 4 (each within the scatter of the next).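

In this assay, among the compounds shown here, the amide hydrogen on this carbonyl carbon appears for the first time, and hydrogen in place of methyl on the amide-type nitrogen gives no change at the digits printed from compound 3 to compound 4 (within the scatter) in this series. Benzylamino gives no change at the digits printed from compound 1 to compound 4 (within the scatter) when it replaces 1,2,3,4-tetrahydroisoquinolin-2-yl, and no change at the digits printed from compound 2 to compound 4 (within the scatter) when it replaces the 5-fluoro analogue of that group. Nothing available explains this result. The compounds shown leave open whether a morpholine or a piperidine amide, without an aromatic ring, or a longer chain such as phenethylamino would behave likewise on this carbonyl carbon.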